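This account rests on a few compounds, and the source may have more. Where it says the series, first, only, none or still open, it means among the compounds named here.

Measured compounds and their values in a functional assay for inhibition, with Homo sapiens as the target; a lower number here means a stronger inhibitor, a higher number a weaker inhibitor:
compound 1, `c1cc(Nc2nccc(-c3ccco3)n2)cc(-n2ccnc2)c1`: 800 nM
compound 2, `CN(C)CCCOc1ccc(Nc2nccc(-c3cccnc3)n2)cc1`: 600 nM
compound 3, `c1cc(Nc2nccc(-c3cccs3)n2)cc(-n2ccnc2)c1`: 300 nM

Compound 1 gives the highest of the three numbers in this assay. Its nearest neighbour is compound 2, whose value lies within the scatter of that of compound 1, so no order can be drawn between the two. Compound 3 lies further away: the step of a 2.7-fold lower number from compound 1 to compound 3 (0.43 log units; beyond the scatter) is modest but beyond the scatter, and it follows a single change, thiophen-2-yl in place of furan-2-yl on an aromatic carbon.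

Compound 4, `c1ccc(Nc2nccc(-c3ccco3)n2)cc1`, has not yet been measured in this assay. It differs from compound 1 in one place:
hydrogen in place of 1H-imidazol-1-yl on an aromatic carbon

For the measured compounds named here, none of the measured steps concerns this place. Going by the values given here, the only single-change step, a 2.7-fold lower number from compound 1 to compound 3 (0.43 log units; beyond the scatter), alters the five-membered ring on the other side of the shared core and says nothing about the 1H-imidazol-1-yl group. Compound 2 differs from compound 1 in more than one place, so the two values cannot be read as one change. The expectation for compound 4 therefore rests on the change itself: a group of five heavy atoms leaves and only hydrogen enters, and the step of a 1.9-fold higher number from compound 1 to compound 4 (0.27 log units; within the scatter) is expected to be modest and towards a higher number. Compound 4 is thus estimated at 1500 nM in this assay, with a range from 500 nM to 5000 nM.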

Compound 4, half-maximal inhibitory concentration: 32000 nM
Compound 4: the middle estimate sits 21-fold (1.33 log units) below what was measured; measured number outside the range, above it.
By their numbers in this assay, from the lowest: compounds 3, 2 and 1 (each within the scatter of the next, the first and the last beyond it); then compound 4.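

In this assay, hydrogen in place of 1H-imidazol-1-yl on an aromatic carbon gives a 40-fold higher number from compound 1 to compound 4 (1.60 log units; beyond the scatter) and is a large step, which shows that the activity of compound 1 depends heavily on what stands at this place on the six-membered aromatic ring of carbon only. Of the two single changes made to compound 1, this one has much the greater reach, as thiophen-2-yl in place of furan-2-yl gives only the modest 2.7-fold lower number from compound 1 to compound 3 (0.43 log units; beyond the scatter) in the same assay. Nothing among the data shown explains why losing the 1H-imidazol-1-yl group costs so much.

The compounds shown leave open whether the 1H-imidazol-1-yl group is needed as such, or whether another group at this place, such as an amine, a carboxylic acid or a pyridine ring, would keep the activity of compound 1. They also leave open whether thiophen-2-yl in place of furan-2-yl would bring a similar step in a compound that carries hydrogen at this place.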